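Chloro for trifluoromethyl on a cyclopropyl compound

The compounds below may be only part of what the source reports. "The series", "measured", "known", "first", "only" and "open" are said of these compounds alone.

- compound 1 `N#Cc1ccc(C(O)(c2cocn2)C(F)(F)F)cc1C(F)(F)F` gives 83%
- compound 2 `CCC(O)(c1ccc(C#N)c(C(F)(F)F)c1)C(F)(F)F` gives 70%
- compound 3 `N#Cc1ccc(C(O)(C2CC2)C(F)(F)F)cc1C(F)(F)F` gives 86%

These numbers come from an ADME assay on the whole organism (strain Wistar Han) for pharmacokinetics, with Rattus norvegicus as the target, read by LC-MS, at a dose of 10 mg/kg by the oral route (a lower number here means that a smaller share of the oral dose reaches the circulation, a higher number that a larger share of the oral dose reaches the circulation), and all three compounds differ only in one group on the saturated carbon that also carries the oxygen. Two steps place compound 3 among them: a number 3 percentage points higher from compound 1 to compound 3 (within the scatter) shows no real difference, whereas a number 16 percentage points higher from compound 2 to compound 3 (beyond the scatter) is a clear one.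

Compound 4 `N#Cc1ccc(C(O)(C2CC2)C(F)(F)F)cc1Cl` keeps the cyclopropyl group and changes another place: chloro in place of trifluoromethyl on an aromatic carbon with chloro in place of trifluoromethyl on an aromatic carbon, ortho to a cyano group.

Among the compounds with values here, no measured step touches that aromatic carbon, so the evidence is only indirect. The nearest guide to scale is how far the numbers moved at the other place, where a number 13 percentage points lower from compound 1 to compound 2 (beyond the scatter) was modest and the two steps above were of the sizes given. The data do not show how this swap behaves, so the starting point stays compound 3 at 86% with a wide margin. The expected change is small, an estimated a number 7 percentage points lower from compound 3 to compound 4 (within the scatter) and so no clear shift. For compound 4 the estimated value is 79% with an expected range from 60% to 93% as its two ends.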

Compound 4, oral bioavailability: 80%
Compound 4: the middle estimate sits 1 percentage points below what was measured; measured number inside the range.
By their numbers in this assay, from the lowest: compounds 2, 4, 1 and 3 (each within the scatter of the next, the first and the last beyond it).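

Within the data shown here, this aromatic carbon, ortho to a cyano group, is a new place: the earlier compounds differ only in the group on the saturated carbon that also carries the oxygen, so they say nothing about it. In this assay, among these compounds, the first step at this place is a number 6 percentage points lower from compound 3 to compound 4 (within the scatter), so in this one pair, with cyclopropyl held constant, chloro with 1 heavy atom can stand in place of trifluoromethyl with 4 heavy atoms without a change that can be told apart from ordinary scatter. No measurement shown here gives a reason for this outcome, and one pair cannot show whether the two groups would match in another setting.

The compounds shown leave open whether the same swap would give a similarly small step with ethyl or 1,3-oxazol-4-yl on the saturated carbon in place of cyclopropyl. Going by these compounds, they also leave open how other groups would fare on the aromatic carbon, such as fluoro, bromo, methyl, methoxy or an amine, so the range of groups that this position can accept remains unknown.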